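Trimming the Aniline Chlorines: Expected Effect on Liver-Cell Toxicity

The compounds below may be only part of what the source reports. "The series", "measured", "known", "first", "only" and "open" are said of these compounds alone.

Compound 1 `CC(Sc1nnc(-c2ccncc2)s1)C(=O)Nc1c(Cl)cccc1Cl` was tested in an ADME assay on HepG2 cells (Homo sapiens) for cytotoxicity, with a stated time of 3 days; on this read-out lower numbers stand for higher toxicity in this test and higher numbers for lower toxicity in this test. In this assay compound 1 gives > 50000 nM, which is a limit of the assay rather than a measured number. Its companion compound 2 `O=C(CSc1nnc(-c2ccncc2)s1)Nc1c(Cl)cccc1Cl` gives "not determined" (no result reported) in this assay. Going by the values given here, the only evidence on the measured side is therefore (the limit of > 50000 nM in this assay, at which 1 of the 2 values shown sits), and there is no step between two measured compounds to learn from. Compound 3 `CC(Sc1nnc(-c2ccncc2)s1)C(=O)Nc1ccc(Cl)cc1` differs from compound 1 in one place: 4-chlorophenyl in place of 2,6-dichlorophenyl on an amide-type nitrogen. Whether 4-chlorophenyl in place of 2,6-dichlorophenyl alters toxicity in liver cells cannot be read from the data shown. Since compound 1 already sits at the limit, no change beyond the scatter is expected, and the expected step is a number no higher from compound 1 to compound 3 (the limit leaves the size open). Compound 3 is accordingly estimated at about 50000 nM in this assay, with a range from 15000 nM to 150000 nM, and quite possibly only another limit will be reported.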

Compound 3, half-maximal cytotoxic concentration: > 50000 nM
Compound 3 was reported as a limit; the forecaster's own chance of this, stated with the estimate: 70%; the middle value lies on the limit itself.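

Compound 1 and compound 3 are both reported only as limits in this assay, so no step can be read between them. The compounds shown leave open whether 4-chlorophenyl in place of 2,6-dichlorophenyl on the amide-type nitrogen changes toxicity in liver cells at all.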